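A Fluorine on the Benzyl Ring of Compound 1

The source may hold more compounds than are shown below. What is called first, only, known or untested is meant among the compounds shown, and "the series" means these compounds.

Three compounds have been measured so far in a functional assay on cells for positive allosteric modulation of G-protein coupled receptor 68 (Homo sapiens), read by a luciferase reporter and cAMP accumulation, with a stated time of 30 min, at pH 6.8 and pH 8.3, in the presence of a further agent that is not named here; a lower number here means a less potent compound, a higher number a more potent compound, by a factor of ten per unit of this negative logarithm:
compound 1 `Nc1nc(NCc2ccccc2)nc(-c2ccccc2CO)n1` gives 4.35
compound 2 `CCNc1nc(NCc2ccccc2)nc(-c2ccccc2CO)n1` gives 4.63
compound 3 `Nc1nc(NCc2ccccc2)nc(-c2cc(F)ccc2CO)n1` gives 4.58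

All three share one core and differ only at single points. Compound 1 stands at the low end of these three numbers, yet neither of the other two is separated from it by more than the usual scatter: a number 0.28 log units higher from compound 1 to compound 2 (within the scatter) and a number 0.23 log units higher from compound 1 to compound 3 (within the scatter). Neither change, the ethyl on a ring nitrogen nor the fluoro on the ring that carries the hydroxymethyl group, has moved the number in a way that can be trusted.

Compound 4 `Nc1nc(NCc2ccccc2F)nc(-c2ccccc2CO)n1` is not yet measured. It differs from compound 1 as follows: fluoro in place of hydrogen on an aromatic carbon. Among the measured compounds shown here, the nearest measured step is the one to compound 3, where the same kind of atom was added to a different aromatic ring, a number 0.23 log units higher from compound 1 to compound 3 (within the scatter). For the measured compounds named here, no measured step touches the benzyl ring itself, so there is no direct guide, only the observation that small changes on this core have so far stayed within the scatter.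

The expectation is therefore a small step, if any, a number 0.10 log units higher from compound 1 to compound 4 (within the scatter). Compound 4 is estimated at 4.45, within a range from 4 to 4.9.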

Compound 4, negative logarithm of the antagonist equilibrium constant: 4.27
For compound 4 the middle estimate is 0.18 log units above the measured one; measured number inside the range.
By their numbers in this assay, from the lowest: compounds 4, 1, 3 and 2 (each within the scatter of the next, the first and the last beyond it).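

In this assay, among the compounds shown here, compound 4 gives the first reading on the benzyl ring itself, and the change from benzyl to 2-fluorobenzyl comes to a number 0.08 log units lower from compound 1 to compound 4 (within the scatter) and so cannot be told apart from the hydrogen it replaces. The same kind of swap on the ring that carries the hydroxymethyl group reads a number 0.23 log units higher from compound 1 to compound 3 (within the scatter) and is no clearer, so on both aromatic rings tested, a single fluoro in place of hydrogen has left the number unresolved from that of compound 1. No measurement at hand bears on why the benzyl ring accepts this change in this way.

Among the compounds shown, fluoro is the only group on the benzyl ring and it stands at this one place, ortho to a large group, so it remains open whether a methoxy group, a trifluoromethyl group or an amine there would move the number beyond the scatter. Also open, going by these compounds, is whether fluoro at another carbon of the benzyl ring would read the same as it does in compound 4.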